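Hydrazide to Methylamide on the Shared Core

The source may report more compounds than this note shows. Statements on the series, on what has been measured and on what is new or still open speak of the compounds shown alone.

In an assay on isolated protein for inhibition of LIM domain kinase 1 (Homo sapiens), read by Kinase-Glo, with a stated time of 60 min (a higher number here means a weaker inhibitor, a lower number a stronger inhibitor), compound 1 `Cc1cc(-c2ccc(Cl)cc2)c2c(N)c(C(N)=O)sc2n1` gives 37000 nM.
In this assay compound 2 `NC(=O)c1sc2ccccc2c1O` reaches only the limit > 100000 nM.
In this assay compound 3 `NNC(=O)c1sc2ncccc2c1N` likewise reaches only the limit > 100000 nM.

Compound 3 thus stands at the bottom of what the numbers show, with no measured number of its own; two of the three values sit at this limit (the limit of > 100000 nM in this assay, at which 2 of the 3 values shown sit). Compound 4 `CNC(=O)c1sc2ncccc2c1N` differs from compound 3 in one place: methyl in place of amino on an amide-type nitrogen. Among the compounds with values here, no measured pair shows the effect of such a change, so no direction is known from the data. The expected step from compound 3 to compound 4 in this assay is a number no higher from compound 3 to compound 4 (the limit leaves the size open), with no clear gain beyond the scatter. Compound 4 is therefore expected to give about 100000 nM, between 30000 nM and 300000 nM.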

Compound 4, half-maximal inhibitory concentration: > 100000 nM
Compound 4 gave a limit, no number (the forecaster's own chance of this, stated with the estimate: 60%); the middle value sits exactly at the limit.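

Compound 3 and compound 4 both stop at a limit rather than a number, so no step can be read between them: the limit of > 100000 nM in this assay, at which 3 of the 4 values shown sit.

The compounds shown leave open whether methyl in place of amino on an amide-type nitrogen changes inhibition in this assay at all.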